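The source may hold more compounds than are shown below. What is called first, only, known or untested is meant among the compounds shown, and "the series" means these compounds.

- compound 1 `CC(C)Oc1cc(C(=O)NCCCN(C)C)c2ccccc2n1`: 122000 nM
- compound 2 `CN(C)CCCNC(=O)c1cc(-c2ccccc2)nc2ccccc12`: 44900 nM
- compound 3 `CN(C)CCCNC(=O)c1cc(-c2cccs2)nc2ccccc12`: 40500 nM

In an ADME assay on RD cells (Homo sapiens) for cytotoxicity, read by neutral red uptake, with a stated time of 3 days (on this read-out lower numbers stand for higher toxicity in this test and higher numbers for lower toxicity in this test), compound 1 stands highest of the three measured compounds. Compound 4 `CC(C)Oc1cc(C(=O)NCCN)c2ccccc2n1` differs from it only in the chain: amino in place of (dimethylamino)methyl on a saturated chain carbon, two bonds along the chain from an amide-type nitrogen. For the measured compounds named here, no measured step touches this chain. Phenyl and thiophen-2-yl in place of isopropoxy gave a 2.7-fold lower number from compound 1 to compound 2 (0.43 log units; beyond the scatter) and a 3.0-fold lower number from compound 1 to compound 3 (0.48 log units; beyond the scatter), while thiophen-2-yl in place of phenyl gave a 1.1-fold lower number from compound 2 to compound 3 (0.04 log units; within the scatter). These steps show only the modest spread of the series at another place, so they set no direction. The estimate therefore stays close to compound 1 at 122000 nM, with no step beyond the scatter expected. The expected change is a 1.2-fold lower number from compound 1 to compound 4 (0.09 log units; within the scatter). For compound 4 the estimated value is 100000 nM, with an expected range of 40000 nM to 250000 nM.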

Compound 4, half-maximal cytotoxic concentration: 149000 nM
For compound 4 the middle estimate is 1.5-fold (0.17 log units) below the measured one, within the range that was stated.
By their numbers in this assay, from the lowest: compounds 3 and 2 (each within the scatter of the next); then compounds 1 and 4 (each within the scatter of the next).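

In this assay, for the compounds shown here, the first change to the chain, 3-(dimethylamino)propyl to 2-aminoethyl, gives a 1.2-fold higher number from compound 1 to compound 4 (0.09 log units; within the scatter) and so leaves the two chains unseparated on the core of compound 1. Going by these compounds alone, the earlier steps changed only the isopropoxy position, so this is the first reading of the chain, and here it does not shift the number the way those replacements did. No measurement at hand bears on this result. Still open, on these data alone, is whether 2-aminoethyl behaves alike with phenyl or thiophen-2-yl on the core, and whether a chain ending in a carboxylic acid or a morpholine ring would move the number beyond the scatter.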